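The source may report more compounds than this note shows. Statements on the series, on what has been measured and on what is new or still open speak of the compounds shown alone.

Measured in a functional assay on BV-2 cells (Mus musculus) for inhibition, read by Griess assay, with a stated time of 24 h; a higher number here means a weaker inhibitor, a lower number a stronger inhibitor:
- Compound 1 `C=CCc1ccc(OC)c(-c2cc(CN3CCN(CC(=O)OCC)CC3)on2)c1`: > 200000 nM, a limit
- Compound 2 `C=CCn1ccc(-c2cc(Br)ccc2OC)n1`: > 200000 nM, a limit
- Compound 3 `C=CCc1ccc(OC)c(-c2ccn(CC=C)n2)c1`: > 200000 nM, a limit

Among the compounds with values here, compound 3 therefore has no numerical value, only a limit, and the series so far offers only (the limit of > 200000 nM in this assay, at which 3 of the 3 values shown sit). The change to compound 4 `C=CCc1ccc(OC)c(-c2ccn(Cc3ccccc3)n2)c1` is phenyl in place of vinyl on a saturated chain carbon bound to an aromatic nitrogen, or allyl to benzyl. Within the data shown here, the only measured step, a step that the two limits leave unreadable from compound 2 to compound 3, is a different change and gives no size to carry over. In this assay, a small shift towards stronger inhibition is expected at best, and another limit is quite likely. The expected step is an at least 1.3-fold lower number from compound 3 to compound 4 (0.12 log units; that floor lies within the scatter). Compound 4 is estimated at 150000 nM, with an expected range of 30000 nM to 400000 nM.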

Compound 4, half-maximal inhibitory concentration: 36000 nM
The estimate for compound 4 lay 4.2-fold (0.62 log units) above the measured number, within the range that was stated.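

At the saturated chain carbon bound to the aromatic nitrogen, the series responds to the substituent: in this assay, phenyl in place of vinyl gives an at least 5.5-fold lower number from compound 3 to compound 4 (0.74 log units; beyond the scatter). Within the data shown here, this is the first step with a readable size, and it sets only a minimum. Compound 3 has a limit rather than a number. Compound 4 is the only compound shown to come off that limit: the limit of > 200000 nM in this assay, at which 3 of the 4 values shown sit.

On these data alone, whether the aromatic ring itself matters or chain size alone is enough remains open, and a propyl or phenethyl group at this place would help separate the two. Also open, as far as these compounds go, is how an amine or carboxylic acid on the benzyl ring would change the number.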